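Swapping an Aryl Amide for a Short Polar Chain

The source may hold more compounds than are shown below. What is called first, only, known or untested is meant among the compounds shown, and "the series" means these compounds.

Compound 3 `CCn1c(C(=O)Nc2ccc(OC(F)(F)F)cc2)ccc1C(CC)(CC)c1ccc(OCCC(O)(CC)CC)c(C)c1` carries a 4-(trifluoromethoxy)phenyl group on its amide-type nitrogen. In an assay on cells for agonist activity at vitamin D3 receptor (Homo sapiens), with a stated time of 96 h (on this read-out higher numbers stand for an effect only at larger amounts of compound and lower numbers for an effect already at smaller amounts), compound 3 reaches only the limit of the assay, > 10000 nM. Two close relatives set the scale. Compound 1 `CCn1c(C(=O)NCCN(C)C)ccc1C(CC)(CC)c1ccc(OCCC(O)(CC)CC)c(C)c1`, which carries a 2-(dimethylamino)ethyl chain on the same nitrogen, gives 82 nM in this assay. Compound 2 `C#CCCOC(=O)c1ccc(C(CC)(CC)c2ccc(OCCC(O)(CC)CC)c(C)c2)n1CC`, with a (but-3-yn-1-yl)oxy ester in place of the amide, gives 6030 nM.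

Compound 4 `CCn1c(C(=O)NC(CC(=O)O)C(=O)OC)ccc1C(CC)(CC)c1ccc(OCCC(O)(CC)CC)c(C)c1` differs from compound 3 in one place: a group of 9 heavy atoms (5 carbon, 4 oxygen; no ring) in place of a group of 11 heavy atoms (7 carbon, 1 oxygen, 3 fluorine; one six-membered aromatic ring of carbon only), on an amide-type nitrogen. Among the measured compounds shown here, the steps that bear on this change are an at least 120-fold higher number from compound 1 to compound 3 (2.08 log units; beyond the scatter), which measures the move from the small chain to the aryl group, and a 74-fold higher number from compound 1 to compound 2 (1.87 log units; beyond the scatter), which shows that the ester also loses much against that chain; an at least 1.6-fold higher number from compound 2 to compound 3 (0.21 log units; that floor lies within the scatter) rests partly on the limit (the limit of > 10000 nM in this assay, at which 1 of the 3 values shown sits). For the measured compounds named here, the new group of compound 4 is, like that of compound 1, a short open chain rather than an aromatic ring, so a return toward the better numbers is expected, though no measured compound carries such an oxygen-rich group on that nitrogen, which keeps the expectation uncertain. Compound 4 is therefore expected to give 1500 nM, with a range from 200 nM to 10000 nM. The expected step is an at least 6.6-fold lower number from compound 3 to compound 4 (0.82 log units; beyond the scatter), a large fall in the number.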

Compound 4, half-maximal effective concentration: 26 nM
Beside the measured number, compound 4's estimate is 58-fold (1.76 log units) above it, outside the stated range (below it).
By their numbers in this assay, from the lowest: compound 4; then compound 1; then compound 2. At a limit, above all of these: compound 3.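

The amide-type nitrogen takes more than the 2-(dimethylamino)ethyl chain: a group of only carbon and oxygen, with no nitrogen in it, gives a 3.2-fold lower number from compound 1 to compound 4 (0.50 log units; beyond the scatter) in this assay and so a nitrogen in that chain is not needed for a low number. On the carbonyl carbon, this amide with its open chain gives a 230-fold lower number from compound 2 to compound 4 (2.37 log units; beyond the scatter) in place of the (but-3-yn-1-yl)oxy ester, which puts the two amides with short open chains far from the ester in the same assay. The step away from the 4-(trifluoromethoxy)phenyl group, an at least 380-fold lower number from compound 3 to compound 4 (2.58 log units; beyond the scatter) in size, is only a floor, and the true step could be larger: the limit of > 10000 nM in this assay, at which 1 of the 4 values shown sits.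

The group of compound 4 holds both a carboxylic acid and a methyl ester, and the compounds shown do not tell which of the two parts goes with the low number. As far as these compounds go, how a chain of carbon only, a chain ending in a hydroxyl, or a pyridine ring would fare on that nitrogen stays open, and with a single aryl amide in view, it is also open whether other aromatic rings there would end at the limit as well.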